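This account rests on a few compounds, and the source may have more. Where it says the series, first, only, none or still open, it means among the compounds named here.

Measured so far:

compound 1 `O=C(NCc1ccccc1)c1cc(Oc2cccc(NC(=S)Nc3cccc(C(F)(F)F)c3)c2)ccn1`: 75000 nM
compound 2 `O=C(c1cc(Oc2cccc(NC(=S)Nc3cccc(C(F)(F)F)c3)c2)ccn1)N1CCCC1`: 35400 nM
compound 3 `O=C(NCc1ccccc1)c1cc(Oc2cccc(NC(=S)Nc3ccc(OC(F)(F)F)cc3)c2)ccn1`: a limit, > 100000 nM

In a functional assay on MDA-MB-231 cells (Homo sapiens) for cytotoxicity, read by MTT assay, with a stated time of 48 h (on this read-out higher numbers stand for weaker inhibition and lower numbers for stronger inhibition), compound 1 gives 75000 nM, and compound 2 gives 35400 nM. For compound 3 the assay reports only a limit, > 100000 nM, which is the floor at which one of the three values sits (the limit of > 100000 nM in this assay, at which 1 of the 3 values shown sits). The change from compound 1 to compound 2 is pyrrolidin-1-yl in place of benzylamino on a carbonyl carbon; it gave a 2.1-fold lower number from compound 1 to compound 2 (0.33 log units; beyond the scatter). Compound 3 differs from compound 1 by 4-(trifluoromethoxy)phenyl in place of 3-(trifluoromethyl)phenyl on an amide-type nitrogen, which gave an at least 1.3-fold higher number from compound 1 to compound 3 (0.12 log units; that floor lies within the scatter). Compound 4 `O=C(c1cc(Oc2cccc(NC(=S)Nc3ccc(OC(F)(F)F)cc3)c2)ccn1)N1CCCC1` has not yet been measured; it differs from compound 3 by pyrrolidin-1-yl in place of benzylamino on a carbonyl carbon, the same change as that from compound 1 to compound 2, at the same place. Since compound 3 is known only as a limit, the step from compound 3 to compound 4 is expected to be about an at least 1.4-fold lower number from compound 3 to compound 4 (0.15 log units; that floor lies within the scatter), resting on the earlier step of a 2.1-fold lower number from compound 1 to compound 2 (0.33 log units; beyond the scatter). Compound 4 is therefore estimated at 70000 nM, with a fair chance that this assay again reports only a limit.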

Compound 4, half-maximal inhibitory concentration: 37800 nM
The estimate for compound 4 lay 1.9-fold (0.27 log units) above the measured number; measured number inside the range.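

In this assay, pyrrolidin-1-yl in place of benzylamino on the carbonyl carbon gives an at least 2.6-fold lower number from compound 3 to compound 4 (0.42 log units; beyond the scatter), so the direction of the change carries over to the second core: the same change on two cores in this assay, a 2.1-fold lower number (0.33 log units; beyond the scatter) from compound 1 to compound 2 and an at least 2.6-fold lower number (0.42 log units; beyond the scatter) from compound 3 to compound 4; the limit leaves it open whether they differ. Compound 3 is known only as a limit, > 100000 nM, so the size of this step on its core is not fixed, and any match or mismatch in size between the two cores remains unshown. In the pyrrolidin-1-yl amides, 4-(trifluoromethoxy)phenyl in place of 3-(trifluoromethyl)phenyl gives a 1.1-fold higher number from compound 2 to compound 4 (0.03 log units; within the scatter), and the benzylamino pair cannot settle whether this change behaves alike on both cores: the same change on two cores in this assay, an at least 1.3-fold higher number (0.12 log units; that floor lies within the scatter) from compound 1 to compound 3 and a 1.1-fold higher number (0.03 log units; within the scatter) from compound 2 to compound 4; the limit leaves it open whether they differ.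

The compounds shown leave open how a piperidine or morpholine amide would compare with the pyrrolidin-1-yl amides. They also leave open how a 3-(trifluoromethoxy)phenyl or 4-(trifluoromethyl)phenyl group would read, so the placing and the identity of the substituent cannot be told apart.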